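Swapping Bromine for Chlorine on Two Related Cores

The source may report more compounds than this note shows. Statements on the series, on what has been measured and on what is new or still open speak of the compounds shown alone.

Two pairs of compounds share a single change: a chloro in place of a bromo on an aromatic carbon. The first pair is measured. Compound 1 `COc1ccc(C2=NN(C3=NC(=O)/C(=C4\C(=O)Nc5ccc(Br)cc54)S3)C(c3ccc(Cl)cc3)C2)cc1` in a functional assay on cells (Cancer cell lines, Homo sapiens) for cytotoxicity, read by sulforhodamine B assay, with a stated time of 48 h (on this read-out higher numbers stand for weaker inhibition of growth and lower numbers for stronger inhibition of growth), gives 1480 nM. Compound 2 `COc1ccc(C2=NN(C3=NC(=O)/C(=C4\C(=O)Nc5ccc(Cl)cc54)S3)C(c3ccc(Cl)cc3)C2)cc1` in this assay gives 430 nM. The change chloro in place of bromo on an aromatic carbon produced a 3.4-fold lower number from compound 1 to compound 2 (0.54 log units; beyond the scatter).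

The second pair rests on a different core. Compound 3 `COc1ccc(-c2cc(-c3ccc(Cl)cc3)n(C3C(=O)Nc4ccc(Br)cc43)n2)cc1` in this assay gives 16700 nM, the highest of the three numbers; its gap to compound 1 and its wider gap to compound 2 both lie beyond the scatter. How the core of compound 3 differs from the core of compound 1 is not broken down here. Compound 4 `COc1ccc(-c2cc(-c3ccc(Cl)cc3)n(C3C(=O)Nc4ccc(Cl)cc43)n2)cc1` has not yet been measured in this assay. It differs from compound 3 by chloro in place of bromo on an aromatic carbon, the same kind of change as between compound 1 and compound 2, at a place described in the same words.

For the measured compounds named here, the step from compound 3 to compound 4 in this assay is expected to be a 2.6-fold lower number from compound 3 to compound 4 (0.41 log units; beyond the scatter), set beside the earlier step, because a 3.4-fold lower number from compound 1 to compound 2 (0.54 log units; beyond the scatter) is the only measured example of this change and it came on a different core, so a somewhat smaller step is expected. For compound 4 in this assay the estimated value is 6500 nM, expected to fall between 2500 nM and 16000 nM.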

Compound 4, concentration for total growth inhibition: 14400 nM
For compound 4 the middle estimate is 2.2-fold (0.35 log units) below the measured one, and the stated range covers the measured number.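

On the second core, chloro in place of bromo gives a 1.2-fold lower number from compound 3 to compound 4 (0.06 log units; within the scatter) in this assay and so leaves compound 3 and compound 4 indistinguishable on this read-out. Set beside the earlier step, this shows that the size of the change did not carry over from the first core to the second: the same change on two cores in this assay, a 3.4-fold lower number (0.54 log units; beyond the scatter) from compound 1 to compound 2 and a 1.2-fold lower number (0.06 log units; within the scatter) from compound 3 to compound 4, 3.0-fold (0.47 log units) apart, beyond the scatter of two such steps
A step measured on one core in this series is therefore no safe guide to the same step on the other, although this rests on a single pair of compounds per core and does not show why the two cores differ or whether the same gap would appear in another test.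

Only bromo and chloro appear at this place on the aromatic ring, so the compounds shown leave open how a fluoro group, a methyl group or an amine there would behave on either core. They also leave open whether the two cores would still respond differently to this change if the methoxy group shared by all four compounds gave way to a carboxylic acid or a longer chain.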